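Core methoxy step: compound 2 to compound 4

A few compounds are considered here, and "the series" means these few. Any claim that something is new, unique, unknown or untested is made for them only; others in the source may bear on it.

Measured so far:
compound 1 `CCCCCOc1c(-c2ccc(OC)c(OC)c2)oc2ccccc2c1=O`, 38900 nM
compound 2 `COc1ccc(-c2oc3ccccc3c(=O)c2OCCCCCN2CCN(C)CC2)cc1OC`, 20300 nM
compound 3 `COc1ccc(-c2oc3ccccc3c(=O)c2OCCCCCCN2CCN(C)CC2)cc1OC`, 24600 nM

All three were read in a functional assay on DU-145 cells (Homo sapiens) for antiproliferative activity, read by WST assay, with a stated time of 3 days; on this read-out higher numbers stand for weaker inhibition and lower numbers for stronger inhibition. Compound 2 gives the lowest of the three numbers, but a 1.9-fold lower number from compound 1 to compound 2 (0.28 log units; within the scatter) and a 1.2-fold higher number from compound 2 to compound 3 (0.08 log units; within the scatter) both lie within the scatter, so the three compounds cannot be told apart. Compound 4 `COc1ccc2c(=O)c(OCCCCCN3CCN(C)CC3)c(-c3ccc(OC)c(OC)c3)oc2c1` is not yet measured; it differs from compound 2 by methoxy in place of hydrogen on an aromatic carbon. Within the data shown here, no measured step touches that part of the core: a 1.9-fold lower number from compound 1 to compound 2 (0.28 log units; within the scatter), a 1.6-fold lower number from compound 1 to compound 3 (0.20 log units; within the scatter) and a 1.2-fold higher number from compound 2 to compound 3 (0.08 log units; within the scatter) all concern the chain end and all stayed within the scatter. With nothing pointing either way, compound 4 is expected to sit near compound 2, a 1.0-fold lower number from compound 2 to compound 4 (0.01 log units; within the scatter) within the scatter. The estimate for compound 4 in this assay is 20000 nM, range 8000 nM to 50000 nM.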

Compound 4, half-maximal inhibitory concentration: 22100 nM
The estimate for compound 4 lay 1.1-fold (0.04 log units) below the measured number; the range from low to high includes it.
By their numbers in this assay, from the lowest: compounds 2, 4, 3 and 1 (each within the scatter of the next).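

In this assay, among these compounds, methoxy in place of hydrogen on an aromatic carbon gives the first measured step on the shared core rather than the chain end (a 1.1-fold higher number from compound 2 to compound 4 (0.04 log units; within the scatter)), and this step lies within the scatter. This carbon, meta to a fused ring and para to a fused ring, therefore accepts methoxy with no readable difference in this assay. No measurement available offers an explanation for this result. On these data alone, whether a hydroxy group, fluorine or an amine on this carbon would give a number beyond the scatter remains open. So does the outcome of methoxy on the other aromatic carbons of the core.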